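Pentyl Chain on the Aryl Group: Expected Cytotoxicity

A few compounds are considered here, and "the series" means these few. Any claim that something is new, unique, unknown or untested is made for them only; others in the source may bear on it.

Three analogues of a shared core have been measured in an ADME assay on HFF cells (Homo sapiens) for cytotoxicity, read by MTT assay, with a stated time of 72 h; on this read-out lower numbers stand for stronger inhibition and higher numbers for weaker inhibition. Compound 1 `O=C1O[C@H]([C@@H](O)Cn2cc(-c3cc(F)cc(F)c3)nn2)C(OCc2ccccc2)=C1OCc1ccccc1` returns only a limit of the assay, > 100000 nM. Compound 2 `O=C1O[C@H]([C@@H](O)Cn2cc(CNS(=O)(=O)c3ccc(F)cc3)nn2)C(OCc2ccccc2)=C1OCc1ccccc1` gives 30 nM. Compound 3 `Cc1ccc(-c2cn(C[C@H](O)[C@H]3OC(=O)C(OCc4ccccc4)=C3OCc3ccccc3)nn2)cc1` likewise returns only a limit, > 100000 nM. The step of an at least 3300-fold lower number from compound 1 to compound 2 (3.52 log units; beyond the scatter) is large, as is its reverse at least 3300-fold higher number from compound 2 to compound 3 (3.52 log units; beyond the scatter); the step that the two limits leave unreadable from compound 1 to compound 3 cannot be read, since the limit of > 100000 nM in this assay, at which 2 of the 3 values shown sit, holds both of its ends.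

Compound 4 `CCCCCc1ccc(-c2cn(C[C@H](O)[C@H]3OC(=O)C(OCc4ccccc4)=C3OCc3ccccc3)nn2)cc1` differs from compound 3 by butyl in place of hydrogen on a saturated chain carbon bound to an aromatic carbon. Within the data shown here, no measured step touches this part of the molecule: the measured steps exchange the aryl substituent itself, and the two compounds carrying a plain aryl group, compound 1 and compound 3, both sit at the limit. Compound 4 is therefore expected to stay at or near that limit, with a step of a number no higher from compound 3 to compound 4 (the limit leaves the size open) that does not rise beyond the scatter. Compound 4 is estimated at 100000 nM, within a range of 30000 nM to 300000 nM.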

Compound 4, half-maximal inhibitory concentration: > 100000 nM
Compound 4 was reported as a limit; the forecaster's own chance of this, stated with the estimate: 80%; the middle value sits exactly at the limit.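

Extending methyl to pentyl on the aryl group does not move the result off the limit in this assay: compound 4 gives > 100000 nM, which is a limit of the assay and not a number. The step of an at least 3300-fold higher number from compound 2 to compound 4 (3.52 log units; beyond the scatter) is large and beyond the scatter, so a 4-pentylphenyl group does not yield a value like the one obtained with the (((4-fluorophenyl)sulfonyl)amino)methyl group. The steps linking compound 4 with compound 1 and compound 3 cannot be read, since both ends of each lie at the same limit: the limit of > 100000 nM in this assay, at which 3 of the 4 values shown sit.

On these data alone, how far compound 1, compound 3 and compound 4 lie past that limit stays open, so the pentyl chain has no readable effect of any size. Also open, as far as these compounds go, is whether a chain carrying an amine or a carboxylic acid in place of pentyl would give a value below the limit.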